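The source may hold more compounds than are shown below. What is called first, only, known or untested is meant among the compounds shown, and "the series" means these compounds.

Compound 1 `CC(=O)N[C@@H]1CCC[C@H](C(=O)Nc2cc(-c3cnn4ccccc34)c(Cl)cn2)C1`: 45000 nM. Compound 2 `CC(=O)N[C@@H]1CCC[C@H](C(=O)Nc2cc(-c3cnc(C)n3C)c(Cl)cn2)C1`: a limit, > 1000000 nM.

In a physicochemical assay for solubility, in phosphate buffer, at pH 7.4 (on this read-out lower numbers stand for lower solubility and higher numbers for higher solubility), compound 1 gives 45000 nM. For compound 2 only a limit is known, > 1000000 nM, and it sits at the limit of > 1000000 nM in this assay, at which 1 of the 2 values shown sits. The measured step of an at least 22-fold higher number from compound 1 to compound 2 (1.34 log units; beyond the scatter) accompanies the exchange of the fused group of compound 1 for a single ring. Compound 3 `CC(=O)N[C@@H]1CCC[C@H](C(=O)Nc2cc(-c3cnn4c3CC(C)(C)C4)c(Cl)cn2)C1` carries a group of 10 heavy atoms (8 carbon, 2 nitrogen; one five-membered non-aromatic ring with 1 hetero atom, one five-membered aromatic ring with 2 hetero atoms) in place of a group of 7 heavy atoms (5 carbon, 2 nitrogen; one five-membered aromatic ring with 2 hetero atoms), on an aromatic carbon. This reintroduces a fused bicyclic group, as in compound 1, so a downward step is expected, its size uncertain since compound 2 stands at a limit. Compound 3 is expected to give 200000 nM, between 40000 nM and 1000000 nM, which means an at least 5.0-fold lower number from compound 2 to compound 3 (0.69 log units; beyond the scatter) is expected.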

Compound 3, solubility: 150000 nM
The estimate for compound 3 lay 1.3-fold (0.12 log units) above the measured number, and the stated range covers the measured number.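

In this assay, compound 3 shows both an at least 6.6-fold lower number from compound 2 to compound 3 (0.82 log units; beyond the scatter) and a 3.3-fold higher number from compound 1 to compound 3 (0.52 log units; beyond the scatter). At this position, ortho to a chloro group, a fused group therefore does not settle the number: the fused group with a five-membered non-aromatic ring stands higher than the one with a six-membered aromatic ring. Compound 2 remains a limit, so the first step has no upper bound: the limit of > 1000000 nM in this assay, at which 1 of the 3 values shown sits.

Still open, as far as these compounds go, is whether a group carrying an amine or a carboxylic acid in this place would raise the number as far as 1,2-dimethyl-1H-imidazol-5-yl does.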